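The source may report more compounds than this note shows. Statements on the series, on what has been measured and on what is new or still open speak of the compounds shown alone.

Compound 1 `Cc1ccc(NC2=CC(=O)c3c(nc4n3[C@H]3OC[C@@H](O)[C@H]3OC4)C2=O)cc1C`: 1050 nM
Compound 2 `O=C1C=C(NC2CCCC2)C(=O)c2c1nc1n2[C@H]2OC[C@@H](O)[C@H]2OC1`: > 8000 nM
Compound 3 `O=C1C(N2CCC2)=CC(=O)c2c1nc1n2[C@H]2OC[C@@H](O)[C@H]2OC1`: > 16000 nM

All three share one core and differ only in the group attached to a double-bonded ring carbon. In a functional assay on MGC-803 cells (Homo sapiens) for inhibition, read by sulforhodamine B assay (on this read-out lower numbers stand for stronger inhibition and higher numbers for weaker inhibition), compound 1 gives 1050 nM. For compound 2 the assay reports only a limit, > 8000 nM, so its true number is not known; it sits at the limit of > 8000 nM in this assay, at which 1 of the 3 values shown sits. For compound 3 the read-out is likewise a limit, > 16000 nM, at the limit of > 16000 nM in this assay, at which 1 of the 3 values shown sits.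

Compound 4 `O=C1C=C(Nc2cccc(Cl)c2)C(=O)c2c1nc1n2[C@H]2OC[C@@H](O)[C@H]2OC1` has not yet been measured. Its change from compound 2 is 3-chlorophenyl in place of cyclopentyl on an amine nitrogen. Among the measured compounds shown here, the one measured step that bears on this, an at least 15-fold higher number from compound 1 to compound 3 (1.18 log units; beyond the scatter), shows that replacing the (3,4-dimethylphenyl)amino group with a nitrogen-linked non-aromatic ring gives a much weaker result. Compound 4 brings back a six-membered aromatic ring on the amine nitrogen, as in compound 1, so the expectation is a large drop in number, an at least 5.3-fold lower number from compound 2 to compound 4 (0.72 log units; beyond the scatter), toward the region of compound 1. Compound 4 is therefore estimated at 1500 nM, with a range from 500 nM to 5000 nM.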

Compound 4, half-maximal inhibitory concentration: 1770 nM
The estimate for compound 4 lay 1.2-fold (0.07 log units) below the measured number, within the range that was stated.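

In this assay, the group carried by the amine nitrogen matters even when the nitrogen itself stays in place: an at least 4.5-fold lower number from compound 2 to compound 4 (0.65 log units; beyond the scatter). The earlier step, from compound 1 to compound 3, replaced the whole (3,4-dimethylphenyl)amino group with azetidin-1-yl, so it could not show the effect of the ring on the amine nitrogen alone; here only cyclopentyl gives way to 3-chlorophenyl. The full size of this step cannot be read because compound 2 stands at a limit: the limit of > 8000 nM in this assay, at which 1 of the 4 values shown sits.

The compounds shown do not separate the effect of the aromatic ring from that of its chlorine, a question that a plain phenyl group on the same nitrogen could address. From the compounds shown here alone, how a benzyl group or a longer carbon chain would read there also remains open.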